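One Carbon Longer: Extending the Linker in Two Series

A few compounds are considered here, and "the series" means these few. Any claim that something is new, unique, unknown or untested is made for them only; others in the source may bear on it.

Measured so far in an assay on isolated protein (Cavia porcellus) with Sigma non-opioid intracellular receptor 1 (Homo sapiens) as the target, read by radioligand binding; a higher number here means a weaker inhibitor, a lower number a stronger inhibitor:
compound 1 `COc1ccc(-c2cc(=O)c3cc(OCCCCCN4CCC(O)CC4)ccc3o2)cc1`: 600 nM
compound 2 `COc1ccc(-c2cc(=O)c3cc(OCCCCCCN4CCC(O)CC4)ccc3o2)cc1`: 332 nM
compound 3 `O=c1cc(-c2ccccc2)oc2cc(OCCCCCCN3CCC(O)CC3)ccc12`: 70 nM

Compound 1 and compound 2 differ by (4-hydroxypiperidin-1-yl)methyl in place of 4-hydroxypiperidin-1-yl on a saturated chain carbon, five bonds along the chain from an oxygen on an aromatic ring. That step gave a 1.8-fold lower number from compound 1 to compound 2 (0.26 log units; within the scatter). Compound 3 carries the same kind of chain on a different core; the difference between the two cores is not broken down here. Among the three, compound 3 has the lowest number in this assay, with compound 2 nearest and compound 1 furthest, both gaps beyond the scatter.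

Compound 4 `O=c1cc(-c2ccccc2)oc2cc(OCCCCCCCN3CCC(O)CC3)ccc12` has not yet been measured. It differs from compound 3 by (4-hydroxypiperidin-1-yl)methyl in place of 4-hydroxypiperidin-1-yl on a saturated chain carbon, six bonds along the chain from an oxygen on an aromatic ring. This is the same kind of change as that made from compound 1 to compound 2, but not the same: there it sat five bonds along the chain from an oxygen on an aromatic ring, here six bonds along. Because the earlier step was a 1.8-fold lower number from compound 1 to compound 2 (0.26 log units; within the scatter), a step of similar size is expected here, a 1.4-fold lower number from compound 3 to compound 4 (0.15 log units; within the scatter), resting on that single pair alone. For compound 4 the estimate in this assay is 50 nM, expected to fall between 20 nM and 150 nM.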

Compound 4, half-maximal inhibitory concentration: 19 nM
Estimate against measurement, compound 4: 2.6-fold (0.42 log units) above; the measured number lies below the stated range.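

In this assay, the one-carbon extension on the core of compound 3 gave a 3.7-fold lower number from compound 3 to compound 4 (0.57 log units; beyond the scatter). Set beside the same change on the core of compound 1, the two steps cannot be told apart: the same change on two cores in this assay, a 1.8-fold lower number (0.26 log units; within the scatter) from compound 1 to compound 2 and a 3.7-fold lower number (0.57 log units; beyond the scatter) from compound 3 to compound 4, 2.0-fold (0.31 log units) apart, within the scatter of two such steps. For the compounds shown here, this shows that the change carried over from one core to the other without a detectable difference in step size, but it does not show that the core sets the size of the step or that the two steps are truly equal, since each core offers a single pair, only the step on the core of compound 3 lies beyond the scatter on its own, and the two steps also sit at different places on the chain, five and six bonds along from the oxygen on the aromatic ring.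

The compounds shown leave open whether a still longer chain would lower the number further on either core. They also leave open whether the step would hold with a morpholine in place of the 4-hydroxypiperidin-1-yl group.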